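This account rests on a few compounds, and the source may have more. Where it says the series, first, only, none or still open, it means among the compounds named here.

Of the compounds shown here, two in this set have already been measured in a functional assay on HT-29 cells (Homo sapiens) for inhibition, read by MTT assay; a higher number here means a weaker inhibitor, a lower number a stronger inhibitor. Compound 1, `CCNC(=O)N1CCC(Oc2cc3nccc(Oc4ccc(NC(=O)NN5C(=O)CSC5c5ccc(F)cc5)cc4)c3cc2OC)CC1`, gives 2250 nM in this assay. Compound 2, `COc1cc2c(Oc3ccc(NC(=O)NN4C(=O)CSC4c4ccccc4)cc3)ccnc2cc1OC1CCN(C(=O)NC(C)C)CC1`, gives 1260 nM in this assay. Compound 2 carries the smaller of the two numbers, but compound 1 sits close enough that the gap between them lies within the usual scatter of repeated measurements, so the two cannot be told apart on these data. They also differ from each other in more than one place, so no single structural step can be read out of that pair.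

Compound 3, `COc1cc2c(Oc3ccc(NC(=O)NN4C(=O)CSC4c4cccc(F)c4)cc3)ccnc2cc1OC1CCN(C(=O)NC(C)C)CC1`, has not been measured. It differs from compound 2 in one place only: fluoro in place of hydrogen on an aromatic carbon, in words, fluoro in place of hydrogen on an aromatic carbon. Among the compounds with values here, no measured pair here shows what such a change does, so there is no direct step to lean on. The expected step of a 1.0-fold higher number from compound 2 to compound 3 (0.01 log units; within the scatter) is small, with no direction that goes beyond the scatter. Compound 3 is accordingly estimated at 1300 nM in this assay, within a range from 500 nM to 3500 nM.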

Compound 3, half-maximal inhibitory concentration: 670 nM
Beside the measured number, compound 3's estimate is 1.9-fold (0.29 log units) above it; the measured number falls inside the stated range.
By their numbers in this assay, from the lowest: compounds 3, 2 and 1 (each within the scatter of the next, the first and the last beyond it).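

Within the data shown here, the move from phenyl to 3-fluorophenyl is the first change in one place only that can be read in this assay in this set, and it gives a 1.9-fold lower number from compound 2 to compound 3 (0.27 log units; within the scatter) as its step. This pair therefore shows that a fluoro can sit at this aromatic carbon, meta to a large group, while the number stays within the usual scatter of that of compound 2, so this single step cannot be called a real gain or loss. No measurement shown here offers any explanation for the numbers of these compounds.

As far as these compounds go, what other groups would do at this same carbon stays open: chloro, methoxy, an amine or a carboxylic acid might give a step that clears the scatter, or might again stay within it. From the compounds shown here alone, it is also open whether fluoro on another carbon of this ring would behave as it does here, since a single step from one pair of compounds cannot establish a pattern for the ring as a whole.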